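The source may report more compounds than this note shows. Statements on the series, on what has been measured and on what is new or still open speak of the compounds shown alone.

Measured in a functional assay on MCF7 cells (Homo sapiens) for inhibition, read by sulforhodamine B assay; on this read-out lower numbers stand for stronger inhibition and higher numbers for weaker inhibition:
- Compound 1 `O=C1C(Nc2ccc(I)cc2)=CC(=O)c2c1nc1n2[C@H]2OC[C@@H](O)[C@H]2OC1`: 3890 nM
- Compound 2 `O=C1C(N2CCCC2)=CC(=O)c2c1nc1n2[C@H]2OC[C@@H](O)[C@H]2OC1`: > 16000 nM (a limit of the assay)
- Compound 3 `O=C1C(Nc2ccc(C(F)(F)F)cc2)=CC(=O)c2c1nc1n2[C@H]2OC[C@@H](O)[C@H]2OC1`: > 4000 nM (a limit of the assay)

Compound 1 is the only one of the three with a true number in this assay. Compound 3 has only a limit, > 4000 nM. Its real position is therefore unknown on the side of weaker inhibition.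

Compound 4 `O=C1C(NC2CC2)=CC(=O)c2c1nc1n2[C@H]2OC[C@@H](O)[C@H]2OC1` carries cyclopropyl in place of 4-(trifluoromethyl)phenyl on an amine nitrogen.

Going by the values given here, two measured steps bear on this change. Trifluoromethyl in place of iodo on an aromatic carbon gave an at least 1.0-fold higher number from compound 1 to compound 3 (0.01 log units; that floor lies within the scatter), a floor within the scatter, and it leaves the aromatic ring in place. Pyrrolidin-1-yl in place of (4-iodophenyl)amino on a double-bonded ring carbon gave an at least 4.1-fold higher number from compound 1 to compound 2 (0.61 log units; beyond the scatter), a modest step at the least and beyond the scatter. Among the compounds with values here, this is the only measured step that takes the aromatic ring away, though it also replaces the amine nitrogen's substitution pattern, so it is an imperfect guide.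

On the strength of an at least 4.1-fold higher number from compound 1 to compound 2 (0.61 log units; beyond the scatter), a move towards a higher number, meaning weaker inhibition, is expected, and the expected step is a step that the limit leaves unreadable from compound 3 to compound 4. A limit rather than a number is quite possible. For compound 4 the estimated value is 10000 nM, with an expected range from 4000 nM to 30000 nM.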

Compound 4, half-maximal inhibitory concentration: > 16000 nM
Compound 4: only a limit was reported (the forecaster's own chance of this, stated with the estimate: 50%); middle value at least 1.6-fold (0.20 log units) from the limit.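

In this assay compound 4, with cyclopropyl on the amine nitrogen, gives > 16000 nM, which is a limit of the assay and not a number. Cyclopropyl in place of 4-iodophenyl gave an at least 4.1-fold higher number from compound 1 to compound 4 (0.61 log units; beyond the scatter), so here the aromatic ring goes while the amine nitrogen keeps its hydrogen, a separation that the change to pyrrolidin-1-yl in compound 2 could not offer, and weaker inhibition still follows. The steps to compound 4 from compound 2 and from compound 3 cannot be read, since each joins two limits, and compound 4 shares its limit with compound 2: the limit of > 16000 nM in this assay, at which 2 of the 4 values shown sit.

The compounds shown leave open how weak compound 4 really is, and whether the true number of compound 3 lies close to that of compound 1 or far from it. They also leave open whether a benzyl group or a straight butyl chain on this amine nitrogen would give a true number in this assay, and so whether the aromatic ring must sit directly on the nitrogen.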